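Oxan-3-yl for Oxan-4-yl in a Urea Series

The source may hold more compounds than are shown below. What is called first, only, known or untested is meant among the compounds shown, and "the series" means these compounds.

Three compounds have been measured in a physicochemical assay for lipophilicity, read by HPLC, with a stated time of 90 min, tested at 100 uM; on this read-out lower numbers stand for lower lipophilicity and higher numbers for higher lipophilicity:

Compound 1 `O=C(Nc1ccc(OC(F)(F)F)cc1)NC1CCN(C(=O)C2CCOCC2)CC1` gives 3.26.
Compound 2 `O=C(Nc1ccc(C(F)(F)F)c(F)c1)NC1CCN(C(=O)C2CCOCC2)CC1` gives 3.52.
Compound 3 `O=C(Nc1ccc(OC(F)(F)F)cc1)NC1CCN(C(=O)C2CCCOC2)CC1` gives 3.42.

Compound 1 and compound 3 share a core and differ in one place: oxan-3-yl in place of oxan-4-yl on a carbonyl carbon. In this assay that change made a step of a number 0.16 log units higher from compound 1 to compound 3 (within the scatter), a step that lies within the usual scatter of such measurements. Compound 2 carries a different aryl part, and the difference between its core and that of compound 1 is not broken down here. The numbers for compound 2 and compound 3 lie within the scatter of each other, as do those for compound 2 and compound 1, so no order among them can be claimed.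

Compound 4 `O=C(Nc1ccc(C(F)(F)F)c(F)c1)NC1CCN(C(=O)C2CCCOC2)CC1` has not yet been measured. It stands to compound 2 as compound 3 stands to compound 1: oxan-3-yl in place of oxan-4-yl on a carbonyl carbon. The place of the change is described in the same words for both pairs, so this is the same change carried onto the core of compound 2. Among the measured compounds shown here, the step is expected to be a number 0.16 log units higher from compound 2 to compound 4 (within the scatter), resting on the one earlier example, the step of a number 0.16 log units higher from compound 1 to compound 3 (within the scatter), and on the value of compound 2, 3.52. Because that earlier step of a number 0.16 log units higher from compound 1 to compound 3 (within the scatter) was small, compound 4 is estimated at 3.68, with a likely range from 3.4 to 3.96.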

Compound 4, partition coefficient: 3.84
Estimate against measurement, compound 4: 0.16 log units below, within the range that was stated.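

In this assay, among the compounds shown here, oxan-3-yl in place of oxan-4-yl on a carbonyl carbon gave a number 0.32 log units higher from compound 2 to compound 4 (beyond the scatter) and had earlier given a number 0.16 log units higher from compound 1 to compound 3 (within the scatter) so the change goes the same way on both cores, although only the step on the core of compound 2 lies beyond the usual scatter. With just these two pairs, the shared direction is what has been seen to carry from one core to the other, while it is not shown that the size of the step carries, nor that the direction would hold on any further core in the series. The data offered here contain nothing that explains the step on either core.

The compounds shown leave open how this change behaves when the aryl part carries something else, such as a nitrile, a methoxy group or a chlorine atom in place of the trifluoromethoxy and trifluoromethyl groups seen here. They also leave open how the oxan-3-yl and oxan-4-yl pair compares with other groups on the same carbonyl carbon, such as oxolan-3-yl, cyclohexyl, a piperidine amine or a longer chain ending in a carboxylic acid.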